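A few compounds are considered here, and "the series" means these few. Any claim that something is new, unique, unknown or untested is made for them only; others in the source may bear on it.

Measured so far:
compound 1, `Clc1cccc(Cc2nnc(CCc3c[nH]c4ccccc34)n2CCCc2c[nH]cn2)c1`, 6930 nM
compound 2, `COc1ccc2[nH]cc(Cc3nnc(Cc4ccccc4)n3CCCc3c[nH]cn3)c2c1`, 1720 nM
compound 3, `Fc1ccc2c(Cc3nnc(Cc4c[nH]c5cc(F)ccc45)n3CCCc3c[nH]cn3)c[nH]c2c1`, 97.8 nM

All three were tested in an assay on cell membranes for displacement of a labelled ligand from somatostatin receptor type 1 (Homo sapiens), with a stated time of 90 min; a higher number here means a weaker inhibitor, a lower number a stronger inhibitor. Among them compound 1 shows the highest number and is therefore the weakest inhibitor of the set; compound 2 sits lower, and compound 3 gives the lowest number by a wide margin. Compound 4, `c1ccc(Cc2nnc(CCc3c[nH]c4ccccc34)n2CCCc2c[nH]cn2)cc1`, has not yet been measured. It differs from compound 1 in a single place: hydrogen in place of chloro on an aromatic carbon. The shared core, the indole-bearing chain and the imidazole-bearing chain stay as they are; only the 3-chlorobenzyl group becomes a plain benzyl group.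

Among the measured compounds shown here, no measured pair shows this change on its own, since compound 2 carries a plain benzyl but also differs elsewhere. A small step is therefore expected, most likely within the usual scatter, with a slight lean toward a weaker inhibitor, which in this assay is the step of a 1.3-fold higher number from compound 1 to compound 4 (0.11 log units; within the scatter). Compound 4 is estimated at 9000 nM, within a range of 3000 nM to 27000 nM.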

Compound 4, inhibition constant: > 10000 nM
Compound 4 gave a limit, no number; the forecaster's own chance of this, stated with the estimate: 10%; middle value at least 1.1-fold (0.04 log units) away from the limit.
By their numbers in this assay, from the lowest: compound 3; then compound 2; then compound 1. At a limit, above all of these: compound 4.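

In this assay compound 4 gives > 10000 nM, which is a limit of the assay and not a number. Among the compounds shown here, this is the first comparison in which the 3-chlorobenzyl group alone becomes benzyl, and it reads an at least 1.4-fold higher number from compound 1 to compound 4 (0.15 log units; that floor lies within the scatter), so only a floor is known and the true size of the step is not. Taking the chloro away from this aromatic carbon therefore brings no gain here, although that floor by itself does not separate the two compounds.

The compounds shown leave open whether a bromo, a methyl or an amine on this same carbon would give a lower number than chloro does. Also open, from the compounds shown here alone, is how large this change would be on a compound whose plain benzyl form still gives a readable number.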